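The source may hold more compounds than are shown below. What is called first, only, known or untested is meant among the compounds shown, and "the series" means these compounds.

Measured so far in a physicochemical assay for pharmacokinetics; a lower number here means that the compound disappears faster, a higher number that the compound lasts longer:
- Compound 1 `C[C@@H](NC(=O)OC(C)(C)C)C(=O)Oc1cc(-c2oc3cc(O)cc(O)c3c(=O)c2O)ccc1O`: 0.0000297 h
- Compound 2 `CC(C)(C)OC(=O)NCCCCCC(=O)Oc1cc(-c2oc3cc(O)cc(O)c3c(=O)c2O)ccc1O`: 0.000367 h
- Compound 3 `CC(C)(C)OC(=O)N[C@H]1CC[C@@H](C(=O)Oc2cc(-c3oc4cc(O)cc(O)c4c(=O)c3O)ccc2O)CC1`: 0.000331 h

Compound 2, at 0.000367 h, cannot be told apart from compound 3, at 0.000331 h, as the two lie within the usual scatter of each other. Compound 1, at 0.0000297 h, lies beyond the scatter from compound 2, with the lower number.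

Compound 4 `NCCCCCC(=O)Oc1cc(-c2oc3cc(O)cc(O)c3c(=O)c2O)ccc1O` has not yet been measured in this assay. It comes from compound 2 by one change, hydrogen in place of tert-butoxycarbonyl on an amine nitrogen. Among the compounds with values here, all three measured compounds carry tert-butoxycarbonyl, so no measured pair shows what removing it does. The expectation therefore starts from compound 2 and allows for a move either way. The expected 1.2-fold lower number from compound 2 to compound 4 (0.09 log units; within the scatter) is small and no larger than the scatter. The range stays wide, since the measured values already reach down to compound 1 at 0.0000297 h. For compound 4, the estimated half-life is 0.0003 h, with an expected range from 0.00004 h to 0.002 h.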

Compound 4, half-life: 0.0000458 h
The estimate for compound 4 lay 6.6-fold (0.82 log units) above the measured number, within the range that was stated.
By their numbers in this assay, from the lowest: compounds 1 and 4 (each within the scatter of the next); then compounds 3 and 2 (each within the scatter of the next).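

In this assay, within the data shown here, hydrogen in place of tert-butoxycarbonyl on an amine nitrogen gives an 8.0-fold lower number from compound 2 to compound 4 (0.90 log units; beyond the scatter) and this is the first view of that change, since every earlier compound carried the group. So, on this chain, the group on the nitrogen matters to the read-out, and the free amine does not keep the number of compound 2. The other step, with 5-aminopentyl in place of 1-((tert-butoxycarbonyl)amino)ethyl on a carbonyl carbon, is a 1.5-fold higher number from compound 1 to compound 4 (0.19 log units; within the scatter) and leaves those two compounds indistinguishable, while nothing available explains either step.

On these data alone, whether the same removal lowers the number in compound 1 or compound 3 remains open. Also open, as far as these compounds go, is where an acetyl or a methyl group on that nitrogen would fall relative to compound 2 and compound 4.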